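A few compounds are considered here, and "the series" means these few. Any claim that something is new, unique, unknown or untested is made for them only; others in the source may bear on it.

Of the compounds shown here, three sharing one core have been tested in a functional assay on the whole organism (strain Swiss) with Mus musculus as the target, in the maximal electroshock model, with a stated time of 2 h, at a dose of 300 mg/kg by the intraperitoneal route; a lower number here means a weaker effect, a higher number a stronger effect of the compound at the dose given. Compound 1 `CCC(C(=O)N1CCN(c2ccc(Cl)cc2)CC1)N1C(=O)CCC1=O` gives 25%. Compound 2 `CC(C(=O)N1CCN(c2ccc(Cl)cc2)CC1)N1C(=O)CCC1=O` gives 0%, and compound 3 `CC(C(=O)N1CCN(c2ccc(C(F)(F)F)cc2)CC1)N1C(=O)CCC1=O` gives 0%. Compound 2 thus stands level with compound 3 at the digits reported, the two together the lowest of the three numbers, while the only gap beyond the scatter is a number 25 percentage points lower from compound 1 to compound 2 (beyond the scatter). The other measured step is no change at the digits printed from compound 2 to compound 3 (within the scatter).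

Compound 4 `CC(C(=O)N1CCN(c2cccc(F)c2)CC1)N1C(=O)CCC1=O` has not yet been measured. It differs from compound 2 in one place: 3-fluorophenyl in place of 4-chlorophenyl on an amine nitrogen in a ring. Among the measured compounds shown here, the measured step that bears on this is the one between compound 2 and compound 3, where an exchange of the substituent on an aromatic carbon left the number within the scatter; the step between compound 1 and compound 2 concerns the chain and does not speak to an aryl change. Compound 4 is therefore expected to show a number 3 percentage points higher from compound 2 to compound 4 (within the scatter), that is, no step beyond the scatter. The estimate for compound 4 is 3%, expected to lie between 0% and 15%.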

Compound 4, a percentage reported as activity, at one dose (the size of the read-out at that dose, not a potency): 100%
Compound 4: middle estimate off by 97 percentage points, on the low side; the measured number lies above the stated range.
By their numbers in this assay, from the lowest: compounds 2 and 3 (each within the scatter of the next); then compound 1; then compound 4.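

In this assay, replacing 4-chlorophenyl with 3-fluorophenyl on the amine nitrogen in a ring gives a number 100 percentage points higher from compound 2 to compound 4 (beyond the scatter) and so shows that the read-out responds strongly to the aryl group at this position, which no change at the digits printed from compound 2 to compound 3 (within the scatter) had not revealed. The exchange leaves the heavy-atom count of the group and its counts of hydrogen-bond donors and acceptors unchanged, so these counts do not separate compound 2 from compound 4. Nothing available bears on the reason for this large step.

Compound 4 differs from compound 2 in both the halogen and its place on the ring, so the compounds shown do not tell which of the two matters. They also leave open what a plain phenyl group would give on the same nitrogen, and how 3-fluorophenyl behaves with the longer chain of compound 1.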